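Trading 3-(hydroxymethyl)phenyl for 4-chlorophenyl

This account rests on a few compounds, and the source may have more. Where it says the series, first, only, none or still open, it means among the compounds named here.

In a physicochemical assay for lipophilicity, read by HPLC, at pH 7.5 (on this read-out lower numbers stand for lower lipophilicity and higher numbers for higher lipophilicity), compound 3 `CC[C@@H](Nc1c(C#N)c(-c2ccc(-c3cccc(CO)c3)cc2)nc2cnccc12)C(N)=O` gives 2 as the lowest of three numbers. Compound 1 `CC[C@@H](Nc1c(C#N)c(-c2ccc(-c3cccc(C)c3F)cc2)nc2cnccc12)C(N)=O` gives 3 and compound 2 `CC[C@@H](Nc1c(C#N)c(-c2ccc(-c3cccc(Cl)c3OC)cc2)nc2cnccc12)C(N)=O` gives 3.1 on the same scale. The gap a number 0.10 log units higher from compound 1 to compound 2 (within the scatter) is no real difference. Compound 4 `CC[C@@H](Nc1c(C#N)c(-c2ccc(-c3ccc(Cl)cc3)cc2)nc2cnccc12)C(N)=O` still awaits measurement. It carries 4-chlorophenyl in place of 3-(hydroxymethyl)phenyl on an aromatic carbon. Two measured steps bring in 3-(hydroxymethyl)phenyl: a number 1.00 log units lower from compound 1 to compound 3 (beyond the scatter) and a number 1.10 log units lower from compound 2 to compound 3 (beyond the scatter) are modest and large in size. Losing that group should roughly reverse them, so the expected step is a number 1.00 log units higher from compound 3 to compound 4 (beyond the scatter) in this estimate. For the measured compounds named here, no measured compound carries 4-chlorophenyl, so the range stays wide. Compound 4 is estimated at 3 with a range from 2.6 to 3.4 expected.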

Compound 4, distribution coefficient: 3.1
For compound 4 the middle estimate is 0.10 log units below the measured one; measured number inside the range.
By their numbers in this assay, from the lowest: compound 3; then compounds 1, 2 and 4 (each within the scatter of the next).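

In this assay, the single chlorine of 4-chlorophenyl leaves the reading level with those of the two more heavily substituted rings (steps: a number 0.10 log units higher from compound 1 to compound 4 (within the scatter); no change at the digits printed from compound 2 to compound 4 (within the scatter)). Among these four compounds, only 3-(hydroxymethyl)phenyl stands apart (step: a number 1.10 log units higher from compound 3 to compound 4 (beyond the scatter)), and it is also the only one of the two groups compared here that counts a hydrogen-bond donor. Nothing measured here explains this gap. Still open, as far as these compounds go, is whether an amine or a carboxylic acid on this ring would give a reading nearer that of compound 3, and whether a longer chain ending in a hydroxyl would do the same.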